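Swapping the sulfur-linked arm in a weak cytotoxic series

This account rests on a few compounds, and the source may have more. Where it says the series, first, only, none or still open, it means among the compounds named here.

Measured so far:
compound 1 `Cn1nc(-c2nnc(SCc3c(F)cccc3F)o2)cc1-c1ccc(C(F)(F)F)cc1`: 28200 nM
compound 2 `Cn1nc(-c2nnc(SCCc3ccc(F)cc3)o2)cc1-c1ccc(C(F)(F)F)cc1`: 29200 nM

In a functional assay on Ehrlich cells (Mus musculus) for cytotoxicity, read by MTT assay, with a stated time of 24 h (a higher number here means a weaker inhibitor, a lower number a stronger inhibitor), compound 1 gives 28200 nM and compound 2 gives 29200 nM; these two numbers lie within the scatter of each other, so neither compound stands apart. Compound 3 `Cn1nc(-c2nnc(SCc3cccc([N+](=O)[O-])c3)o2)cc1-c1ccc(C(F)(F)F)cc1` differs from compound 2 by 3-nitrophenyl in place of 4-fluorobenzyl on a saturated chain carbon bound to a sulfur. For the measured compounds named here, the only measured step at this place, a 1.0-fold higher number from compound 1 to compound 2 (0.02 log units; within the scatter), stayed within the scatter. A further change at the same place is therefore expected to leave the number essentially unmoved, the estimated step being a 1.0-fold higher number from compound 2 to compound 3 (0.01 log units; within the scatter). Compound 3 is estimated to give 30000 nM in this assay, with a range from 12000 nM to 75000 nM.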

Compound 3, half-maximal inhibitory concentration: > 100000 nM
Compound 3: no number, only a limit; the forecaster's own chance of this, stated with the estimate: 10%; middle value at least 3.3-fold (0.52 log units) from the limit.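

For the compounds shown here, this position is not as indifferent as the earlier compounds suggested: in this assay, the change to 3-nitrophenyl gives an at least 3.4-fold higher number from compound 2 to compound 3 (0.53 log units; beyond the scatter), and against the other fluorinated arm it gives an at least 3.5-fold higher number from compound 1 to compound 3 (0.54 log units; beyond the scatter). Both steps point to a weaker compound, whereas the two fluorinated arms alone stayed within the scatter. Compound 3 gives > 100000 nM, which is a limit of the assay and not a number, so the true size of the loss stays unknown: the limit of > 100000 nM in this assay, at which 1 of the 3 values shown sits.

On these data alone, whether the loss is tied to the nitro group itself remains open. An amine or a carboxylic acid on the same ring could separate that group from the other changes in this arm.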